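Removing the pyrrolidine ring from a quinoline ether

The source may hold more compounds than are shown below. What is called first, only, known or untested is meant among the compounds shown, and "the series" means these compounds.

Compound 1 `CC(C)Oc1cccc2ccc(N)nc12` gives 437 nM in an assay on cells with melanin-concentrating hormone receptor 1 (Homo sapiens) as the target, read by radioligand binding; a lower number here means a stronger inhibitor, a higher number a weaker inhibitor.
Compound 2 `Nc1ccc2cccc(OC3CCCC3)c2n1` gives only a limit in this assay, > 2000 nM.
Compound 3 `CC(CC(C)(C)C)Oc1cccc2ccc(N3CCCC3)nc12` likewise gives only a limit in this assay, > 2000 nM.

Only compound 1 has a true number; compound 2 and compound 3 sit at the limit of > 2000 nM in this assay, at which 2 of the 3 values shown sit, so compound 3 stands at the weak end of what was recorded, without a number of its own. Compound 4 `CC(CC(C)(C)C)Oc1cccc2cccnc12` differs from compound 3 by hydrogen in place of pyrrolidin-1-yl on an aromatic carbon. Among the compounds with values here, the single measured step, an at least 4.5-fold higher number from compound 1 to compound 2 (0.66 log units; beyond the scatter), concerns the ether group on the oxygen and not the carbon next to the ring nitrogen, so it does not bear on this change. Compound 1 and compound 3 differ in two places, and their values show only that one combination reaches a number while the other does not. With nothing directly comparable, a step in either direction cannot be excluded; the expectation is that compound 4 stays near the limit, a step that the limit leaves unreadable from compound 3 to compound 4. Compound 4 is expected at 3000 nM, within 800 nM to 12000 nM.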

Compound 4, half-maximal inhibitory concentration: > 2000 nM
Compound 4 was reported as a limit; the forecaster's own chance of this, stated with the estimate: 60%; the middle value is on the limit's open side.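

Compound 3 and compound 4 each give only a limit in this assay, not a number, so no step between them can be read: the limit of > 2000 nM in this assay, at which 3 of the 4 values shown sit.

The compounds shown leave open whether hydrogen in place of pyrrolidin-1-yl changes the number in either direction.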